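The source may hold more compounds than are shown below. What is called first, only, known or untested is meant among the compounds shown, and "the series" means these compounds.

Measured so far:
compound 1 `CCOCc1c(C)coc1-c1ccc2c(c1OC)CCCC2(C)C`: 19.8 uM
compound 2 `Cc1coc(-c2ccc3c(c2O)CCCC3(C)C)c1C(=O)O`: 1.7 uM

In a functional assay on ZR-75-1 cells (Homo sapiens) for cytotoxicity, read by sulforhodamine B assay, with a stated time of 3 days (on this read-out higher numbers stand for an effect only at larger amounts of compound and lower numbers for an effect already at smaller amounts), compound 1 holds the higher of the two numbers, and its gap to compound 2 lies beyond the scatter. Compound 3 `COc1c(-c2occ(C)c2COC(C)=O)ccc2c1CCCC2(C)C` keeps the core of compound 1 and changes one place: acetyl in place of ethyl on an oxygen on a saturated carbon. Among the compounds with values here, no measured pair covers this change, so the expectation stays close to compound 1 (19.8 uM), with no step beyond the scatter in this assay and no direction favoured. The expected step is a 1.3-fold lower number from compound 1 to compound 3 (0.12 log units; within the scatter) on this estimate. For compound 3 the estimated value is 15 uM, with an expected range from 6 uM to 40 uM as its bounds.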

Compound 3, concentration for half-maximal effect: 15.5 uM
Compound 3: the middle estimate sits 1.0-fold (0.01 log units) below what was measured, within the range that was stated.
By their numbers in this assay, from the lowest: compound 2; then compounds 3 and 1 (each within the scatter of the next).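

In this assay, acetyl in place of ethyl on an oxygen on a saturated carbon gives a 1.3-fold lower number from compound 1 to compound 3 (0.11 log units; within the scatter). Within the data shown here, this is the first single-place comparison, and on the core of compound 1 it separates ethoxymethyl and acetoxymethyl by no more than the usual scatter. No measurement on hand accounts for this step.

From the compounds shown here alone, whether an amine at this position, or a longer chain such as butyl on the oxygen, would also stay within the scatter remains open. A single pair also leaves open how far this holds for other groups here.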